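This account rests on a few compounds, and the source may have more. Where it says the series, first, only, none or still open, it means among the compounds named here.

Working notes on the series.

Compound 1 `CC(=O)N[C@@H](CSC/C=C(\C)CC/C=C(\C)CCC=C(C)C)C(=O)C=[N+]=[N-]` gives 32200 nM in a functional assay on MOLT-3 cells (Homo sapiens); a lower number here means a stronger inhibitor, a higher number a weaker inhibitor. Compound 2 `CC(=O)N[C@@H](CSC/C=C(\C)CC/C=C(\C)CCC=C(C)C)C(=O)CCl` differs from it by a group of 2 heavy atoms (1 carbon, 1 chlorine; no ring) in place of a group of 3 heavy atoms (1 carbon, 2 nitrogen; no ring), on a carbonyl carbon and gives 1400 nM; the step is a 23-fold lower number from compound 1 to compound 2 (1.36 log units; beyond the scatter). Compound 3 `CC(C)=CCC/C(C)=C/CC/C(C)=C/CSC[C@H](NC(=O)CNC(=O)OC(C)(C)C)C(=O)C=[N+]=[N-]` carries the same warhead as compound 1 on a core that differs by (tert-butoxycarbonyl)amino in place of hydrogen on a saturated chain carbon bound to a carbonyl carbon, and in this assay compound 3 gives 84500 nM, the step being a 2.6-fold higher number from compound 1 to compound 3 (0.42 log units; beyond the scatter). Compound 3 thus stands highest of the three numbers.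

Compound 4 `CC(C)=CCC/C(C)=C/CC/C(C)=C/CSC[C@H](NC(=O)CNC(=O)OC(C)(C)C)C(=O)CCl` is not yet measured. It differs from compound 3 by a group of 2 heavy atoms (1 carbon, 1 chlorine; no ring) in place of a group of 3 heavy atoms (1 carbon, 2 nitrogen; no ring), on a carbonyl carbon, which is the same change, at the same place, that carries compound 1 to compound 2. For the measured compounds named here, that single precedent, a 23-fold lower number from compound 1 to compound 2 (1.36 log units; beyond the scatter), is the only guide here, and there is no second pair in which the core of compound 3 has been tested with a varied warhead. The step from compound 3 to compound 4 in this assay is expected to be about as large as the earlier one, near a 21-fold lower number from compound 3 to compound 4 (1.32 log units; beyond the scatter), because the earlier step of a 23-fold lower number from compound 1 to compound 2 (1.36 log units; beyond the scatter) was large and beyond the scatter. On that basis compound 4 is estimated at 4000 nM, with a likely span from 1500 nM to 12000 nM.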

Compound 4, half-maximal inhibitory concentration: 17500 nM
The estimate for compound 4 lay 4.4-fold (0.64 log units) below the measured number; the measured number lies above the stated range.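

In this assay, chloromethyl on the carbonyl carbon again gives a lower number on the second core (a 4.8-fold lower number from compound 3 to compound 4 (0.68 log units; beyond the scatter)), so the direction of the change carries over from the core of compound 1 to the core of compound 3, but its size does not: the same change on two cores in this assay, a 23-fold lower number (1.36 log units; beyond the scatter) from compound 1 to compound 2 and a 4.8-fold lower number (0.68 log units; beyond the scatter) from compound 3 to compound 4, 4.8-fold (0.68 log units) apart, beyond the scatter of two such steps. Seen from the other side, (tert-butoxycarbonyl)amino raises the number with either group on the carbonyl carbon, and the rise with chloromethyl present (a 13-fold higher number from compound 2 to compound 4 (1.10 log units; beyond the scatter)) differs from the rise seen with the other group: the same change on two cores in this assay, a 2.6-fold higher number (0.42 log units; beyond the scatter) from compound 1 to compound 3 and a 13-fold higher number (1.10 log units; beyond the scatter) from compound 2 to compound 4, 4.8-fold (0.68 log units) apart, beyond the scatter of two such steps. These two comparisons rest on the same four compounds and show that the two changes do not act independently here, but they do not show what sets the size of either step or whether the direction would hold on any further core.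

As far as these compounds go, it remains open whether bromomethyl or fluoromethyl on the carbonyl carbon would follow chloromethyl on these two cores. A free amine in place of (tert-butoxycarbonyl)amino is also an open case, as it could show whether the smaller chloromethyl step persists.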